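The compounds below may be only part of what the source reports. "The series", "measured", "known", "first", "only" and "open" are said of these compounds alone.

Two compounds have been measured in a functional assay on MCF7 cells (Homo sapiens) for cytotoxicity, read by sulforhodamine B assay, with a stated time of 48 h; a higher number here means a weaker inhibitor, a lower number a stronger inhibitor:

Compound 1 `Clc1ccc(-c2csc3ncnc(N4CCN(c5ccccc5)CC4)c23)cc1` gives 34.2 nM.
Compound 2 `O=C1c2ccccc2C(=O)N1Nc1ncnc2scc(-c3ccc(Cl)cc3)c12` gives 39.3 nM.

Among the measured compounds shown here, the two numbers sit within the scatter of each other, so compound 2 and compound 1 cannot be told apart on this assay; compound 2 stands level with its only neighbour.

Compound 3 `O=C1c2ccccc2C(=O)N1Nc1ncnc2scc(-c3ccc([N+](=O)[O-])cc3)c12` differs from compound 2 in one place: nitro in place of chloro on an aromatic carbon. For the measured compounds named here, no pair of measured compounds shows what this exchange does here, so the two measured values give no guide to its size or direction. With the shared core and the rest of the molecule unchanged, the expectation is a step from compound 2 to compound 3 of a 1.5-fold higher number from compound 2 to compound 3 (0.18 log units; within the scatter), which would stay close to the scatter rather than clearly beyond it. On that basis compound 3 is estimated at 60 nM, with a range from 15 nM to 250 nM.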

Compound 3, half-maximal inhibitory concentration: 107 nM
Compound 3: the middle estimate sits 1.8-fold (0.25 log units) below what was measured, and the stated range covers the measured number.
By their numbers in this assay, from the lowest: compounds 1 and 2 (each within the scatter of the next); then compound 3.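

In this assay, among the compounds shown here, nitro in place of chloro on this aromatic ring gives a 2.7-fold higher number from compound 2 to compound 3 (0.43 log units; beyond the scatter), the first change that stands clear of the scatter. This position is therefore not indifferent to what sits on it: the 4-nitrophenyl compound is a modestly weaker inhibitor than the 4-chlorophenyl compound, with three heavy atoms and two hydrogen-bond acceptors entering where one chlorine left. Nothing available accounts for this difference.

A single exchange cannot show whether the loss is specific to nitro or would follow any replacement of chloro, and an amine, a methoxy group or plain hydrogen at this place would help to separate those cases. From the compounds shown here alone, it also remains open whether the same exchange would have a similar effect on compound 1, which carries the same 4-chlorophenyl group.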